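From Compound 2 to Compound 4: Losing a Methoxy Group

This account rests on a few compounds, and the source may have more. Where it says the series, first, only, none or still open, it means among the compounds named here.

In a functional assay on HT-29 cells (Homo sapiens) for cytotoxicity, read by sulforhodamine B assay, with a stated time of 48 h (a lower number here means a stronger inhibitor of growth, a higher number a weaker inhibitor of growth), compound 1 `COc1ccc(C(=O)c2cc(OC)c(OC)c(OC)c2)c(OC)c1O` gives 3460 nM and compound 3 `COc1ccc(C(=O)c2cc(OC)c(OC)c(OC)c2)c(OC)c1NC(C)=O` gives 4330 nM while compound 2 `COc1ccc(C(=O)c2cc(OC)c(OC)c(OC)c2)c(OC)c1N` stands lowest of the three at 32.3 nM on these numbers. Compound 4 `COc1ccc(C(=O)c2cc(OC)c(OC)c(OC)c2)cc1N` differs from compound 2 by hydrogen in place of methoxy on an aromatic carbon with hydrogen in place of methoxy on an aromatic carbon, ortho to an amino group. Among the compounds with values here, compound 4 keeps that amino group, the site of the large steps of a 110-fold lower number from compound 1 to compound 2 (2.03 log units; beyond the scatter) and a 130-fold higher number from compound 2 to compound 3 (2.13 log units; beyond the scatter) while no measured step touches a methoxy group, so no step beyond the scatter is expected in this assay here. The estimated change is a 1.3-fold lower number from compound 2 to compound 4 (0.11 log units; within the scatter) and it is expected to stay within the scatter. For compound 4 the estimated value is 25 nM with a range from 5 nM to 150 nM expected.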

Compound 4, concentration for 50% growth inhibition: 33 nM
Compound 4: the middle estimate sits 1.3-fold (0.12 log units) below what was measured; measured number inside the range.
By their numbers in this assay, from the lowest: compounds 2 and 4 (each within the scatter of the next); then compounds 1 and 3 (each within the scatter of the next).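

In this assay, hydrogen in place of methoxy, ortho to an amino group, gives a 1.0-fold higher number from compound 2 to compound 4 (0.01 log units; within the scatter), so this methoxy group makes no difference that can be read in this assay. The earlier steps shown here all fell at the amino position; this one shows that the low number seen with the amino group does not depend on the methoxy group beside the comparison of these two compounds alone. No measurement at hand offers a reason for this.

On these data alone, whether a larger group at this place, such as ethoxy, or a halogen such as chlorine, would read the same stays open. So does whether the large steps at the amino position would hold without the methoxy group.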